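Trimming the dialkylamino group: from compound 2 to compound 3

The source may hold more compounds than are shown below. What is called first, only, known or untested is meant among the compounds shown, and "the series" means these compounds.

For the measured compounds named here, compound 2 `CC(C)N(c1nc(Cl)nc(N[C@@H](C)c2ccccc2)n1)C(C)C` holds the lowest of the two numbers so far in an ADME assay on the whole organism for inhibition, with Oryza sativa as the target, with a stated time of 4 days (a lower number here means a stronger inhibitor, a higher number a weaker inhibitor), where compound 2 gives 372 nM; its nearest neighbour, compound 1 `C[C@H](Nc1nc(Cl)nc(NC(C)(C)C)n1)c1ccccc1`, gives 3310 nM. Going by the values given here, the single measured step, an 8.9-fold lower number from compound 1 to compound 2 (0.95 log units; beyond the scatter), exchanged a (tert-butyl)amino group for diisopropylamino. Compound 3 `CCCN(CC)c1nc(Cl)nc(N[C@@H](C)c2ccccc2)n1` differs from compound 2 in one place: ethyl(propyl)amino in place of diisopropylamino on an aromatic carbon. Among the compounds with values here, no measured step covers this exact change, and the earlier step concerned a different replacement, so only a small shift in this assay is expected, a 1.3-fold higher number from compound 2 to compound 3 (0.13 log units; within the scatter). Compound 3 is therefore estimated at 500 nM, between 150 nM and 1700 nM.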

Compound 3, half-maximal inhibitory concentration: 479 nM
Compound 3: middle estimate off by 1.0-fold (0.02 log units), on the high side; measured number inside the range.
By their numbers in this assay, from the lowest: compounds 2 and 3 (each within the scatter of the next); then compound 1.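

In this assay, the exchange of diisopropylamino for ethyl(propyl)amino gives a 1.3-fold higher number from compound 2 to compound 3 (0.11 log units; within the scatter), so at this position these two dialkylamino groups cannot be told apart. Both differ clearly from the (tert-butyl)amino group of compound 1, with a 6.9-fold lower number from compound 1 to compound 3 (0.84 log units; beyond the scatter), in the same direction as an 8.9-fold lower number from compound 1 to compound 2 (0.95 log units; beyond the scatter). No evidence is available to explain these results. The compounds shown leave open how dimethylamino or a ring amine such as piperidine would behave at this position. They also leave open what replacing the chloro group with a methoxy group would do.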